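Methylsulfanyl to benzylsulfanyl, carried from one core to another

The source may report more compounds than this note shows. Statements on the series, on what has been measured and on what is new or still open speak of the compounds shown alone.

Compound 1 `CSc1nc2c(C)nsc2n1[C@H]1C[C@H](O)[C@@H](CO)O1` and compound 2 `Cc1nsc2c1nc(SCc1ccccc1)n2[C@H]1C[C@H](O)[C@@H](CO)O1` share a core and differ only in that compound 2 carries phenyl in place of hydrogen on a saturated chain carbon bound to a sulfur. In a functional assay on L1210 cells (Mus musculus) for antiproliferative activity (a lower number here means a stronger inhibitor, a higher number a weaker inhibitor), compound 1 gives only a limit, > 100000 nM. Compound 2 also gives only a limit in this assay, > 100000 nM. The change a step that the two limits leave unreadable from compound 1 to compound 2 therefore cannot be sized, because the limit of > 100000 nM in this assay, at which 2 of the 3 values shown sit, holds for both of them. Compound 3 `CSc1nc2sncc2n1[C@H]1C[C@H](O)[C@@H](CO)O1` rests on a different core; the difference between the two cores is not broken down here. In this assay, for the measured compounds named here, compound 3 gives 20000 nM, the only plain number among the three. Compound 4 `OC[C@H]1O[C@@H](n2c(SCc3ccccc3)nc3sncc32)C[C@@H]1O` differs from compound 3 by phenyl in place of hydrogen on a saturated chain carbon bound to a sulfur, the same change that separates compound 2 from compound 1, made at the same kind of place. Since the measured pair shows only two limits, there is no readable size to carry over, and the expected step of a 1.5-fold higher number from compound 3 to compound 4 (0.18 log units; within the scatter) is set close to zero with wide uncertainty. On that basis compound 4 is estimated at 30000 nM in this assay, within a range expected from 7000 nM to 150000 nM.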

Compound 4, half-maximal inhibitory concentration: 2200 nM
Beside the measured number, compound 4's estimate is 14-fold (1.13 log units) above it; the measured number lies below the stated range.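

In this assay, the change from methylsulfanyl to benzylsulfanyl gives a 9.1-fold lower number from compound 3 to compound 4 (0.96 log units; beyond the scatter), so on the core of compound 3 the added phenyl goes with a lower number, a step beyond the usual scatter. The same change on the core of compound 1 cannot be read, since compound 1 and compound 2 both stand at a limit of the assay rather than at a number: the limit of > 100000 nM in this assay, at which 2 of the 4 values shown sit. The series therefore shows the step on one core only; it does not show that the change carries from one core to another, nor that it fails to.

On these data alone, it remains open whether a longer chain on the sulfur, such as phenethyl, or a plain alkyl chain such as butyl, would keep the lower number on the core of compound 3. As far as these compounds go, it is also open whether a benzyl ring bearing a chlorine or an amine would bring the core of compound 1 to a readable number.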